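A few compounds are considered here, and "the series" means these few. Any claim that something is new, unique, unknown or untested is made for them only; others in the source may bear on it.

The two benzamides measured so far share one core and differ in both the ring on the amide nitrogen and the cycloalkyl ether. Compound 1 `COc1ccc(C(=O)Nc2c(F)cccc2Cl)cc1OC1CCCC1` has the lowest of the two numbers: in an assay on isolated protein for inhibition of phosphodiesterase 4A (Sus scrofa) (a higher number here means a weaker inhibitor, a lower number a stronger inhibitor), compound 1 gives 240 nM. Its nearest neighbour, compound 2 `COc1ccc(C(=O)Nc2c(F)cccc2F)cc1OC1CCCCC1`, gives 400 nM in this assay, a gap that lies within the usual scatter, so the two cannot be ranked against each other. Among the measured compounds shown here, no pair differing in a single place has been measured, so the series offers no calibrated step for the change now considered. Compound 3 `COc1ccc(C(=O)Nc2ccncc2)cc1OC1CCCC1` carries pyridin-4-yl in place of 2-chloro-6-fluorophenyl on an amide-type nitrogen. Without a measured precedent, the size of this step is uncertain; a moderate shift toward a higher number is expected, with a wide margin. Compound 3 is therefore estimated at 800 nM in this assay, between 200 nM and 3200 nM, which would mean a step of a 3.3-fold higher number from compound 1 to compound 3 (0.52 log units; beyond the scatter).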

Compound 3, half-maximal inhibitory concentration: 800 nM
Beside the measured number, compound 3's estimate shows no gap at the digits printed; low and high end bracket the measured number.
By their numbers in this assay, from the lowest: compounds 1, 2 and 3 (each within the scatter of the next, the first and the last beyond it).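

With compound 3, the series gains its first step in a single place: on an amide-type nitrogen, pyridin-4-yl in place of 2-chloro-6-fluorophenyl gives, in this assay, a 3.3-fold higher number from compound 1 to compound 3 (0.52 log units; beyond the scatter), a modest change. The position therefore accepts a ring with one hetero atom and no halogen while inhibition remains measurable, with compound 3 at 800 nM. Nothing measured here accounts for the size of this step, which one exchange alone cannot assign to the loss of the halogens or the entry of the ring nitrogen.

Still open, going by these compounds, is how a plain phenyl or a pyridin-3-yl on the same nitrogen would compare, as either could help separate those two changes. Compound 1 and compound 2 differ in two places, so the separate contribution of the cycloalkyl ether also remains unread.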